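Series notes: from compound 3 to compound 4

This account rests on a few compounds, and the source may have more. Where it says the series, first, only, none or still open, it means among the compounds named here.

Measured compounds in a functional assay on HEK293 cells with D(4) dopamine receptor (Homo sapiens) as the target, read by FLIPR; on this read-out higher numbers stand for larger maximal responses and lower numbers for smaller maximal responses: compound 1 `O/N=C(/CCN1CCN(c2ccccn2)CC1)c1cc(F)cc(F)c1` gives 70%; compound 2 `CO/N=C(\CCN1CCN(c2ccccn2)CC1)c1ccc(Cl)cc1` gives 87%; compound 3 `CO/N=C(/CCN1CCN(c2ccccn2)CC1)c1ccc(Cl)cc1` gives 68%.

Compound 3 stands lowest of the three numbers. Its nearest neighbour is compound 1, which lies within the scatter of it; the furthest is compound 2, which lies beyond the scatter. Among the compounds with values here, the single step between compounds that differ in one place is a number 19 percentage points lower from compound 2 to compound 3 (beyond the scatter), a modest change that rests on (the fact that compounds 2 and 3 differ only in the configuration as drawn).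

Compound 4 `CO/N=C(/CCN1CCN(c2ccccn2)CC1)c1cc(C)cc(C)c1` differs from compound 3 by 3,5-dimethylphenyl in place of 4-chlorophenyl on a carbon with a double bond to nitrogen. Within the data shown here, no measured step alters the ring on that carbon, so the step from compound 2 to compound 3 does not bear on this change. Compound 1 carries another ring at the same place, yet it also differs in the oxime, so its number offers only a loose comparison and sits within the scatter of compound 3. Among the measured compounds shown here, with no step that bears on the change, no movement beyond the scatter is expected, and the estimated step is no change at the digits printed from compound 3 to compound 4 (within the scatter). Compound 4 is therefore expected to give 68%, with a range from 50% to 85%.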

Compound 4, largest response reached (reported as efficacy), in percent of the reference or control that the assay uses: 83%
Compound 4: middle estimate off by 15 percentage points, on the low side; the range from low to high includes it.
By their numbers in this assay, from the lowest: compounds 3 and 1 (each within the scatter of the next); then compounds 4 and 2 (each within the scatter of the next).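

In this assay, the ring on the carbon with a double bond to nitrogen proves to be a position that affects the maximal response: with the rest of the structure held, 3,5-dimethylphenyl in place of 4-chlorophenyl gives a number 15 percentage points higher from compound 3 to compound 4 (beyond the scatter). Within the data shown here, the earlier single-place step changed only the configuration of the double bond, so this is the first step to show an effect from changing the ring itself. The available evidence does not bear on this ring change.

From the compounds shown here alone, it remains open which feature of the two rings carries the step, and a plain phenyl or a cyclohexyl ring at the same place would help to separate them. Going by these compounds, whether the ring change gives a similar step with the double bond drawn E, as in compound 2, also remains open.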